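The source may report more compounds than this note shows. Statements on the series, on what has been measured and on what is new or still open speak of the compounds shown alone.

In an assay on cells for inhibition of alkaline phosphatase, tissue-nonspecific isozyme (Homo sapiens), read by luminescence, with stated times of 7 min and 20 min (a lower number here means a stronger inhibitor, a higher number a weaker inhibitor), compound 1 `CCCNc1nn2c(=O)cc(C(F)(F)F)nc2s1` gives 1440 nM, and compound 2 `CCCCNc1nn2c(=O)cc(C(F)(F)F)nc2s1` gives 880 nM. The change between them, (methyl in place of hydrogen on a saturated chain carbon, three bonds along the chain from a nitrogen on an aromatic ring), made a step of a 1.6-fold lower number from compound 1 to compound 2 (0.21 log units; within the scatter). Compound 3 `COc1ccccc1-c1nn2c(=O)cc(C(F)(F)F)nc2s1` carries a different core, and how it differs from the core of compound 1 is not broken down here. In this assay compound 3 gives 3480 nM. Compound 4 `CCOc1ccccc1-c1nn2c(=O)cc(C(F)(F)F)nc2s1` has not yet been measured. It differs from compound 3 by methyl in place of hydrogen on a saturated chain carbon bound to an oxygen on an aromatic ring, the same kind of change as from compound 1 to compound 2, though at a different place: there the methyl entered three bonds along the chain from a nitrogen on an aromatic ring, here it enters bound to an oxygen on an aromatic ring. The step expected here, a 1.3-fold lower number from compound 3 to compound 4 (0.13 log units; within the scatter), is set beside the measured step of a 1.6-fold lower number from compound 1 to compound 2 (0.21 log units; within the scatter) and rests on it. Compound 4 is therefore expected to give about 2600 nM, between 1200 nM and 6000 nM.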

Compound 4, half-maximal inhibitory concentration: 4520 nM
Compound 4: the middle estimate sits 1.7-fold (0.24 log units) below what was measured, and the stated range covers the measured number.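

Lengthening methoxy to ethoxy in this assay gives only a small step (a 1.3-fold higher number from compound 3 to compound 4 (0.11 log units; within the scatter)). Set beside the same kind of change on the core of compound 1, this step does not stand apart: the same change on two cores in this assay, a 1.6-fold lower number (0.21 log units; within the scatter) from compound 1 to compound 2 and a 1.3-fold higher number (0.11 log units; within the scatter) from compound 3 to compound 4, 2.1-fold (0.33 log units) apart, within the scatter of two such steps. On these two cores, then, adding this methyl leaves the number within the usual scatter, but this does not show that the change acts alike on both, as the steps are too small to show a direction and the methyl enters at different places.

The compounds shown leave open whether a longer chain on the oxygen, such as propoxy, would move the number beyond the scatter. On these data alone, whether an amine at that place would do so also stays open.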